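This account rests on a few compounds, and the source may have more. Where it says the series, first, only, none or still open, it means among the compounds named here.

Compound 1 `Cc1cc(C)c(CN2CCc3c(Cl)cc([C@@H](CO)[C@@H]4CCOC4)c(Cl)c3C2=O)c(=O)[nH]1` gives 3 10^-6 cm/s in an ADME assay on MDCK cells (Canis lupus familiaris) for permeability, read by LC-MS, with a stated time of 90 min, tested at 2 uM; a higher number here means that the compound crosses the layer faster, a lower number that the compound crosses the layer more slowly.
Compound 2 `Cc1cc(C)c(CN2CCc3c(Cl)cc([C@@H](CO)[C@@H]4CCCO4)c(Cl)c3C2=O)c(=O)[nH]1` gives 4.3 10^-6 cm/s in this assay.
Compound 3 `COC(c1cc(Cl)c2c(c1Cl)C(=O)N(Cc1c(C)cc(C)[nH]c1=O)CC2)C1CCOCC1` gives 13.3 10^-6 cm/s; 16.5 10^-6 cm/s (2 entries) in this assay.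

On the numbers shown, compound 2 has the highest single value of the two compounds that carry a hydroxymethyl group, but its nearest neighbour is compound 1, and the step of a 1.4-fold higher number from compound 1 to compound 2 (0.16 log units; within the scatter) lies within the scatter, so the two cannot be ordered. Compound 3 sits well apart from both, and the spread of its repeat entries, (the several entries of compound 3 in this assay, 13.3 10^-6 cm/s; 16.5 10^-6 cm/s (2 entries)), shows how much a repeated measurement of this kind can move on its own.

Compound 4 `Cc1cc(C)c(CN2CCc3c(Cl)cc([C@@H](C)CO)c(Cl)c3C2=O)c(=O)[nH]1` has not yet been measured. It differs from compound 2 by a group of 4 heavy atoms (3 carbon, 1 oxygen; no ring) in place of a group of 8 heavy atoms (6 carbon, 2 oxygen; one five-membered non-aromatic ring with 1 hetero atom), on an aromatic carbon: a 1-(hydroxymethyl)ethyl group now stands where the oxolane-bearing group stood, so the hydroxymethyl is kept while the five-membered ring is lost. Among the measured compounds shown here, no measured step changes the same part of the molecule in the same way; the only step within the shared core, from compound 1 to compound 2, moved the attachment point of the oxolane without changing its size and stayed within the scatter. The step from compound 2 to compound 4 is therefore expected to be small, a 1.2-fold lower number from compound 2 to compound 4 (0.09 log units; within the scatter), with the number for compound 4 estimated at 3.5 10^-6 cm/s, somewhere between 1.5 10^-6 cm/s and 8 10^-6 cm/s.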

Compound 4, apparent permeability: 15 10^-6 cm/s
Compound 4: the middle estimate sits 4.3-fold (0.63 log units) below what was measured; measured number above the stated range.
By their numbers in this assay, from the lowest: compounds 1 and 2 (each within the scatter of the next); then compound 4.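

In this assay this position responds to the size of the group and not only to small shifts within it: replacing the oxolane-bearing group with 1-(hydroxymethyl)ethyl gives a 3.5-fold higher number from compound 2 to compound 4 (0.54 log units; beyond the scatter) and a 5.0-fold higher number from compound 1 to compound 4 (0.70 log units; beyond the scatter), whereas moving the oxolane attachment point gave only a 1.4-fold higher number from compound 1 to compound 2 (0.16 log units; within the scatter). The hydroxymethyl stays through this change and the leaving and entering groups carry the same number of hydrogen-bond donors, so the rise in the number is not tied to a change in either, while the ring, a hydrogen-bond acceptor and a defined stereocentre all go together. The compounds give no measured reason for the rise, and the only direct view of repeat variation is this one: the several entries of compound 3 in this assay, 13.3 10^-6 cm/s; 16.5 10^-6 cm/s (2 entries)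

The compounds shown do not separate the loss of the ring from the loss of its oxygen or from the drop in heavy atoms, as all of these change in the same step. From the compounds shown here alone, whether a cyclopentyl group in place of the oxolane, a longer chain in place of the methyl of the 1-(hydroxymethyl)ethyl group, or an amine in place of its hydroxyl would follow compound 4 remains open.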